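Mirror image of compound 2 at the assay limit

This account rests on a few compounds, and the source may have more. Where it says the series, first, only, none or still open, it means among the compounds named here.

Measured in a physicochemical assay, read by spectrophotometry, with a stated time of 30 min; a higher number here means that more compound is needed for the effect, a lower number that less compound is needed:
- compound 1 `O=C1c2c(O)cc(O)cc2O[C@@H](c2ccccc2O)[C@@H]1O`: > 100000 nM, a limit
- compound 2 `O=C1c2c(O)cc(O)cc2O[C@H](c2c(O)cccc2O)[C@H]1O`: > 100000 nM, a limit

Compound 2 stands at > 100000 nM, which is a limit and not a number. The whole set looks the same: the limit of > 100000 nM in this assay, at which 2 of the 2 values shown sit. Compound 3 `O=C1c2c(O)cc(O)cc2O[C@@H](c2c(O)cccc2O)[C@@H]1O` is the next entry, and it relates to compound 2 as follows: the two compounds have the same atoms and bonds and differ only in configuration as drawn: 2 of 2 stereo elements differ (all stereocentres are inverted: mirror images); a stereocentre at a saturated ring carbon is drawn R in compound 2 and S in compound 3; a stereocentre at a saturated ring carbon is drawn R in compound 2 and S in compound 3. Going by the values given here, no measured step is available to size this change in this assay, and no step beyond the scatter is expected. The expected step, an estimate only, is a step that the limit leaves unreadable from compound 2 to compound 3. The estimated value for compound 3 is 150000 nM, with an expected range of 100000 nM to 300000 nM.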

Compound 3, half-maximal effective concentration: 100000 nM
Estimate against measurement, compound 3: 1.5-fold (0.18 log units) above; low and high end bracket the measured number.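

In this assay, going by these compounds alone, compound 3 gives 100000 nM, the first reading in this set that is a number and not a limit. Compound 2, its mirror image, stands at > 100000 nM, which is a limit. The inversion of both stereocentres gives a number no higher from compound 2 to compound 3 (the limit leaves the size open), and the hydroxy in place of hydrogen on an aromatic carbon gives a number no higher from compound 1 to compound 3 (the limit leaves the size open). Neither step can be read, so neither change can be sized: the limit of > 100000 nM in this assay, at which 2 of the 3 values shown sit.

From the compounds shown here alone, whether either change has any effect in this assay stays open. Also open, going by these compounds, is how an amine or a carboxylic acid in place of a hydroxy on the aromatic carbon would read.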